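Amine swap on the carbonyl of compound 2

The compounds below may be only part of what the source reports. "The series", "measured", "known", "first", "only" and "open" are said of these compounds alone.

In a functional assay on A549 cells (Homo sapiens) for antiproliferative activity, read by sulforhodamine B assay, with a stated time of 48 h (a lower number here means a stronger inhibitor, a higher number a weaker inhibitor), compound 1 `COc1ccc(-c2oc3c(OC)c(OC)cc(OCCCC(=O)N4CCN(C)CC4)c3c(=O)c2O)cc1` gives only a limit of the assay, > 40000 nM and no number. Among the measured compounds shown here, compound 2 `CCCCCN(C)C(=O)CCCCCOc1cc(OC)c(OC)c2oc(-c3ccc(OC)cc3)c(O)c(=O)c12` gives 17200 nM as the only actual number so far. For the measured compounds named here, the single measured step is an at least 2.3-fold lower number from compound 1 to compound 2 (0.36 log units; beyond the scatter) and gives only weak guidance on the next change. Compound 3 `COc1ccc(-c2oc3c(OC)c(OC)cc(OCCCCCC(=O)NCc4ccccn4)c3c(=O)c2O)cc1` follows with ((pyridin-2-yl)methyl)amino in place of methyl(pentyl)amino on a carbonyl carbon on a carbonyl carbon, ((pyridin-2-yl)methyl)amino in place of methyl(pentyl)amino. The expected step is a 1.1-fold higher number from compound 2 to compound 3 (0.04 log units; within the scatter) and thus none beyond the scatter in this assay as far as can be judged. Compound 3 is estimated at 19000 nM (range 7000 nM to 40000 nM).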

Compound 3, half-maximal inhibitory concentration: > 40000 nM
Compound 3: only a limit was reported; the forecaster's own chance of this, stated with the estimate: 25%; at least 2.1-fold (0.32 log units) between middle value and limit.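

In this assay, ((pyridin-2-yl)methyl)amino in place of methyl(pentyl)amino on a carbonyl carbon gives an at least 2.3-fold higher number from compound 2 to compound 3 (0.36 log units; beyond the scatter), showing that the amine on this carbonyl can shift the read-out. The step from compound 1 to compound 3 cannot be read: both values are limits. The weak end of the series therefore has little resolution: the limit of > 40000 nM in this assay, at which 2 of the 3 values shown sit.

Open, from the compounds shown here alone, is whether benzylamine, lacking the ring nitrogen of ((pyridin-2-yl)methyl)amino, or dimethylamine, with shorter chains than methyl(pentyl)amino, would give a measurable number. Also open, going by these compounds, is how a longer chain to the carbonyl would read.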